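The compounds below may be only part of what the source reports. "The series", "measured", "known", "first", "only" and "open" are said of these compounds alone.

Measured compounds:
- compound 1 `COc1cccc(-c2csc(N/N=C/c3ccco3)n2)c1`, 6780 nM
- compound 2 `COc1cccc(-c2csc(N/N=C/c3c[nH]c4ccccc34)n2)c1`, 800 nM
- compound 3 `COc1cccc(-c2csc(N/N=C(\C)c3cccs3)n2)c1`, 551 nM

In an assay on isolated protein for inhibition of Amine oxidase [flavin-containing] B (Homo sapiens), read by fluorescence (on this read-out lower numbers stand for stronger inhibition and higher numbers for weaker inhibition), compound 1 gives the highest of the three numbers. Compound 2 sits at 800 nM, a step beyond the scatter, and compound 3 at 551 nM, further still. Compound 1 is thus the weakest inhibitor of this set.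

Compound 4 `CCC(CC)=NNc1nc(-c2cccc(OC)c2)cs1` is not yet measured. It differs from compound 1 in one place: a group of 6 heavy atoms (5 carbon, 1 nitrogen; no ring) in place of a group of 7 heavy atoms (5 carbon, 1 nitrogen, 1 oxygen; one five-membered aromatic ring with 1 hetero atom), on a nitrogen on an aromatic ring. In words, a group of 6 heavy atoms (5 carbon, 1 nitrogen; no ring) replaces a group of 7 heavy atoms (5 carbon, 1 nitrogen, 1 oxygen; one five-membered aromatic ring with 1 hetero atom), on a nitrogen on an aromatic ring. Within the data shown here, no measured pair shows this kind of exchange, so the direction rests only on the spread seen among compounds 1, 2 and 3.

Because compound 1 stands at 6780 nM while compound 3 reaches 551 nM, the ring-free variant is expected to move, if at all, toward lower numbers, with a step of a 1.7-fold lower number from compound 1 to compound 4 (0.23 log units; within the scatter) expected to be modest. Compound 4 is estimated at 4000 nM, within a range of 1000 nM to 16000 nM.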

Compound 4, half-maximal inhibitory concentration: 772 nM
Compound 4: the middle estimate sits 5.2-fold (0.71 log units) above what was measured; the whole stated range lies above it.
By their numbers in this assay, from the lowest: compounds 3, 4 and 2 (each within the scatter of the next); then compound 1.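

Exchanging the group that holds the five-membered aromatic ring for the ring-free group gives, in this assay, an 8.8-fold lower number from compound 1 to compound 4 (0.94 log units; beyond the scatter), so a ring is not required at this place on the nitrogen for a lower number. Compound 4 at 772 nM falls in with compound 2 at 800 nM and compound 3 at 551 nM, which leaves compound 1 standing apart, and groups with and without a ring are found together in that cluster. Nothing available accounts for this step.

Going by these compounds, how a longer chain, a saturated cyclohexane ring or an amine would read at this place remains open. On these data alone, it is also open whether the step would hold if a carboxylic acid took the place of the methoxy group on the shared core.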